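The source may hold more compounds than are shown below. What is called first, only, known or untested is meant among the compounds shown, and "the series" means these compounds.

Two compounds share a core carrying a benzyl group that bears a chloromethyl substituent. Compound 1 `Nc1nc(Cl)c2ncn(Cc3ccccc3CCl)c2n1` has an amino group on the core, while compound 2 `ClCc1ccc(Cn2cnc3ncnc(Cl)c32)cc1` has a hydrogen there and the chloromethyl group in a different position on the benzyl ring. In a functional assay on HT-29 cells (Homo sapiens) for cytotoxicity, read by sulforhodamine B assay, with a stated time of 48 h (on this read-out higher numbers stand for weaker inhibition of growth and lower numbers for stronger inhibition of growth), compound 1 gives 19100 nM. In this assay compound 2 gives 3630 nM, the lowest of the two numbers recorded and well beyond the scatter from compound 1, so compound 2 is the stronger grower inhibitor of the pair.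

Compound 3 `ClCc1ccc(Cn2cnc3nc(Cl)nc(Cl)c32)cc1` is compound 2 with one change: chloro in place of hydrogen on an aromatic carbon. Among the measured compounds shown here, no measured pair shows what this kind of change does, so the step is expected to be small, likely within the scatter. The step from compound 2 to compound 3 is estimated at a 1.5-fold lower number from compound 2 to compound 3 (0.16 log units; within the scatter). Compound 3 is expected to give about 2500 nM, somewhere from 800 nM to 8000 nM.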

Compound 3, concentration for total growth inhibition: > 100000 nM
Compound 3: no number, only a limit; the forecaster's own chance of this, stated with the estimate: 0%; at least 40-fold (1.60 log units) between middle value and limit.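

In this assay, a single chloro on an aromatic carbon, between two ring nitrogen atoms, proves to be far from a small change: the step is an at least 27-fold higher number from compound 2 to compound 3 (1.44 log units; beyond the scatter). Among the compounds shown here, compound 1 and compound 2 differ in more than one place, so this is the first pair to isolate this position, and it shows that growth inhibition here can depend strongly on one added atom. For compound 3, the result is a limit and not a number, so the step gives only a minimum size: the limit of > 100000 nM in this assay, at which 1 of the 3 values shown sits.

The compounds shown leave open whether this sharp weakening is specific to chloro or would follow any group placed at this position. A methyl or methoxy group there, on the otherwise unchanged structure of compound 2, would help separate those two possibilities.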